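Swapping Methyl for Oxan-4-yl on the Aromatic Nitrogen

The source may report more compounds than this note shows. Statements on the series, on what has been measured and on what is new or still open speak of the compounds shown alone.

Of the compounds shown here, three with a shared core have been measured in a physicochemical assay for solubility, in phosphate buffer, at pH 7.4; on this read-out lower numbers stand for lower solubility and higher numbers for higher solubility. Compound 1 `CN(C)C(=O)CN1CCC(c2cc3c(-c4ccc(=O)n(C5CCC5)c4)ccnc3[nH]2)CC1` gives only a limit of the assay, > 1000000 nM. Compound 3 `CN(C)C(=O)CN1CCC(c2cc3c(-c4ccc(=O)n(C)c4)ccnc3[nH]2)CC1` likewise gives only a limit, > 1000000 nM. Compound 2 `CC(C)n1nc(-c2ccnc3[nH]c(C4CCN(CC(=O)N(C)C)CC4)cc23)ccc1=O` gives a real number, 11000 nM. Compound 3 therefore stands at the limit of > 1000000 nM in this assay, at which 2 of the 3 values shown sit, not at a number. The change from compound 1 to compound 3, methyl in place of cyclobutyl on an aromatic nitrogen, gives a step that the two limits leave unreadable from compound 1 to compound 3. The other step, an at least 90-fold higher number from compound 2 to compound 3 (1.95 log units; beyond the scatter), alters a different part of the molecule and says little about the aromatic nitrogen. Compound 4 `CN(C)C(=O)CN1CCC(c2cc3c(-c4ccc(=O)n(C5CCOCC5)c4)ccnc3[nH]2)CC1` differs from compound 3 by oxan-4-yl in place of methyl on an aromatic nitrogen. Since both compound 1 with cyclobutyl and compound 3 with methyl sit at the limit described in the limit of > 1000000 nM in this assay, at which 2 of the 3 values shown sit, a group of comparable size on the same nitrogen is expected to leave the value at or near that limit. The expected step is a number no higher from compound 3 to compound 4 (the limit leaves the size open). Compound 4 is therefore estimated at 1000000 nM, within 300000 nM to 3000000 nM, most likely reported again only as a limit.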

Compound 4, solubility: 840000 nM
Beside the measured number, compound 4's estimate is 1.2-fold (0.08 log units) above it; low and high end bracket the measured number.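

Of the three compounds that differ only on this aromatic nitrogen, compound 4 alone gives a real number in this assay, and the other two give a limit: the limit of > 1000000 nM in this assay, at which 2 of the 4 values shown sit. For the compounds shown here, this number allows steps to be stated for the first time at this position, an at least 1.1-fold lower number from compound 3 to compound 4 (0.07 log units; that floor lies within the scatter) and an at least 1.1-fold lower number from compound 1 to compound 4 (0.07 log units; that floor lies within the scatter), though each is only a floor. Going by these compounds alone, with methyl, cyclobutyl and oxan-4-yl, the nitrogen therefore shows no step that can be called real on this read-out, even with the added ring and its oxygen.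

On these data alone, how far compound 1 and compound 3 truly lie from compound 4 stays open, since their limits hide their real values. Also open, as far as these compounds go, is whether an amine such as piperidin-4-yl, or a chain ending in a carboxylic acid, on the same nitrogen would give a step beyond the scatter.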